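Trimming One Methoxy Group from Compound 1

The source may hold more compounds than are shown below. What is called first, only, known or untested is meant among the compounds shown, and "the series" means these compounds.

Compound 1 `COc1ccc(CNc2nc3cc(N)cc(N)c3nc2-c2ccccc2)cc1OC` was tested in a functional assay on IGROV-1 cells (Homo sapiens) for inhibition, read by sulforhodamine B assay, with a stated time of 48 h (on this read-out lower numbers stand for stronger inhibition of growth and higher numbers for weaker inhibition of growth), and gives 40700 nM, the lowest of the two numbers shown. Compound 3 `CCOC(=O)[C@H](CCC(=O)O)NC(=O)c1ccc(Oc2nc3cc(N)cc(N)c3nc2-c2ccccc2)cc1` gives 79400 nM in this assay, and the two values lie within the usual scatter of each other. For compound 2 `COc1cc(CNc2nc3cc(N)cc(N)c3nc2-c2ccccc2)cc(OC)c1OC` the read-out in this assay is a limit of the assay, < 50200 nM, not a number. The step that the limit leaves unreadable from compound 1 to compound 2 cannot be sized because of the limit of < 50200 nM in this assay, at which 1 of the 3 values shown sits. Compound 4 `COc1ccc(CNc2nc3cc(N)cc(N)c3nc2-c2ccccc2)cc1` has not yet been measured; it differs from compound 1 by hydrogen in place of methoxy on an aromatic carbon. Going by the values given here, the only measured step at this position is unreadable, so no shift beyond the scatter is expected in this assay. Compound 4 is therefore estimated to give 40000 nM, within 15000 nM to 110000 nM, an expected step of a 1.0-fold lower number from compound 1 to compound 4 (0.01 log units; within the scatter).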

Compound 4, concentration for total growth inhibition: 26900 nM
Beside the measured number, compound 4's estimate is 1.5-fold (0.17 log units) above it; low and high end bracket the measured number.
By their numbers in this assay, from the lowest: compounds 4, 1 and 3 (each within the scatter of the next, the first and the last beyond it).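

In this assay, going by these compounds alone, the only readable step on this ring is a 1.5-fold lower number from compound 1 to compound 4 (0.18 log units; within the scatter). Cutting 3,4-dimethoxyphenyl back to 4-methoxyphenyl therefore leaves the number within the scatter, so this methoxy group can go without a measurable shift. The earlier compounds could not show this, as the step from compound 1 to compound 2 cannot be read: the limit of < 50200 nM in this assay, at which 1 of the 4 values shown sits.

The compounds shown leave open whether a hydroxyl group, an amine or a fluorine atom on this aromatic carbon would move the number beyond the scatter. On these data alone, whether losing the remaining methoxy group as well would do so also stays open.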